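Dropping a Methoxy Group on a Quinolone-Type Core

This account rests on a few compounds, and the source may have more. Where it says the series, first, only, none or still open, it means among the compounds named here.

Compound 1 `CN[C@@H]1CCN(c2cc3c(cc2F)c(=O)c(C(=O)O)cn3Cc2ccc(-c3ccccc3)cc2)C1` gives 34800 nM in an assay on isolated protein for inhibition of DNA topoisomerase 1 (Homo sapiens), with a stated time of 15 min; a higher number here means a weaker inhibitor, a lower number a stronger inhibitor.
Compound 2 `CN[C@@H]1CCN(c2c(F)cc3c(=O)c(C(=O)O)cn(Cc4ccc(-c5ccccc5)cc4)c3c2OC)C1` gives 57700 nM in this assay.
Compound 3 `CNCCCNc1c(F)cc2c(=O)c(C(=O)O)cn(Cc3ccc(-c4ccccc4)cc3)c2c1OC` gives 101000 nM in this assay.

Compounds 2 and 3 share a core and differ in one place: (3-(methylamino)propyl)amino in place of 3-(methylamino)pyrrolidin-1-yl on an aromatic carbon. That change gave a 1.8-fold higher number from compound 2 to compound 3 (0.24 log units; within the scatter). Compound 2 also stands beside compound 1, which differs from it by hydrogen in place of methoxy on an aromatic carbon; that step was a 1.7-fold lower number from compound 2 to compound 1 (0.22 log units; within the scatter).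

Compound 4 `CNCCCNc1cc2c(cc1F)c(=O)c(C(=O)O)cn2Cc1ccc(-c2ccccc2)cc1` has not yet been measured in this assay. It differs from compound 3 by hydrogen in place of methoxy on an aromatic carbon. Within the data shown here, this is the same kind of change as the one from compound 2 to compound 1, but not the same: in compound 2 the place is ortho to a 3-(methylamino)pyrrolidin-1-yl group, whereas in compound 3 it is ortho to a (3-(methylamino)propyl)amino group; the rest of the surroundings read alike.

The step from compound 3 to compound 4 is expected to be about a 1.7-fold lower number from compound 3 to compound 4 (0.23 log units; within the scatter), because the earlier example of this change gave a 1.7-fold lower number from compound 2 to compound 1 (0.22 log units; within the scatter), a step inside the scatter. Compound 4 is therefore estimated at 60000 nM, with a likely range from 30000 nM to 120000 nM.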

Compound 4, half-maximal inhibitory concentration: 63600 nM
Compound 4: middle estimate off by 1.1-fold (0.03 log units), on the low side, within the range that was stated.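

In this assay, hydrogen in place of methoxy gave a 1.6-fold lower number from compound 3 to compound 4 (0.20 log units; within the scatter), and this step agrees with the one seen on the core carrying the 3-(methylamino)pyrrolidin-1-yl group: the same change on two cores in this assay, a 1.7-fold lower number (0.22 log units; within the scatter) from compound 2 to compound 1 and a 1.6-fold lower number (0.20 log units; within the scatter) from compound 3 to compound 4, 1.0-fold (0.02 log units) apart, within the scatter of two such steps. The side-chain change, (3-(methylamino)propyl)amino in place of 3-(methylamino)pyrrolidin-1-yl, gave a 1.8-fold higher number from compound 1 to compound 4 (0.26 log units; within the scatter), and it also agrees with its earlier counterpart: the same change on two cores in this assay, a 1.8-fold higher number (0.24 log units; within the scatter) from compound 2 to compound 3 and a 1.8-fold higher number (0.26 log units; within the scatter) from compound 1 to compound 4, 1.0-fold (0.02 log units) apart, within the scatter of two such steps. Among these compounds, each change therefore gave a similar result on both cores, but with every step inside the scatter, this shows only that neither change moved the number measurably in these four compounds, not that either one truly strengthens or weakens inhibition.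

The compounds shown leave open whether a larger step would appear with an ethoxy group or a chlorine atom in place of the methoxy, or with a longer chain ending in a primary amine in place of the side chains tested. They also leave open how these changes would behave if the carboxylic acid were replaced by an amide.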